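The compounds below may be only part of what the source reports. "The series", "measured", "known", "first", "only" and "open" are said of these compounds alone.

The measured compounds:
Compound 1 `CCOCCn1c(N2CCN(C)CC2)nc2ccccc21` gives 10 nM in a functional assay on ileum for inhibition of histamine H1 receptor (Cavia porcellus); on this read-out lower numbers stand for stronger inhibition and higher numbers for weaker inhibition.
Compound 2 `CCCCCN1CCN(c2nc3ccccc3n2CCOCC)CC1` gives 30 nM in this assay.

Compound 1 stands with the lower of the two numbers; the step of a 3.0-fold higher number from compound 1 to compound 2 (0.48 log units; beyond the scatter) separates it from compound 2. Compound 3 `CCCC(C)n1c(N2CCN(C)CC2)nc2ccccc21` differs from compound 1 by 1-methylbutyl in place of 2-ethoxyethyl on an aromatic nitrogen. Going by the values given here, the only measured step, a 3.0-fold higher number from compound 1 to compound 2 (0.48 log units; beyond the scatter), concerns butyl in place of hydrogen on a saturated chain carbon bound to an amine nitrogen in a ring, which is not the aromatic nitrogen changed here, so no measured step bears directly on this change. Among the compounds with values here, the chain that leaves and the chain that enters are of equal size, but the sort of group exchanged has no precedent among the measured compounds. A modest weakening is expected for compound 3 in this assay, as the step of a 2.5-fold higher number from compound 1 to compound 3 (0.40 log units; beyond the scatter). Compound 3 is therefore estimated at 25 nM, with a range from 6 nM to 100 nM.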

Compound 3, half-maximal inhibitory concentration: 1400 nM
The estimate for compound 3 lay 56-fold (1.75 log units) below the measured number, outside the stated range (above it).
By their numbers in this assay, from the lowest: compound 1; then compound 2; then compound 3.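

Placing 1-methylbutyl instead of 2-ethoxyethyl on the aromatic nitrogen gives a 140-fold higher number from compound 1 to compound 3 (2.15 log units; beyond the scatter) in this assay, which shows that this position is highly sensitive to the identity of its chain. That step is far larger than a 3.0-fold higher number from compound 1 to compound 2 (0.48 log units; beyond the scatter) at the other end of the molecule, even though the two chains exchanged here have the same count of heavy atoms, so a matching count does not preserve the number. The data at hand offer no measured explanation for this loss.

On these data alone, it remains open whether the step follows the loss of the ether oxygen or the methyl branch of the new chain, which a straight pentyl chain on the same nitrogen would help to separate. Also open, as far as these compounds go, is whether a terminal hydroxyl or amine on that chain would restore the lower number.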